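Chain length and amine on a shared core

The source may hold more compounds than are shown below. What is called first, only, known or untested is meant among the compounds shown, and "the series" means these compounds.

Measured so far:
compound 1 `CN(C)CCn1c(N)c(-c2nc3ccccc3[nH]2)c2nc(C#N)c(C#N)nc21` — 8320 nM
compound 2 `CCN(CC)CCCn1c(N)c(-c2nc3ccccc3[nH]2)c2nc(C#N)c(C#N)nc21` — 1870 nM
compound 3 `CCCCn1c(N)c(-c2nc3ccccc3[nH]2)c2nc(C#N)c(C#N)nc21` — a limit of the assay, > 50000 nM

In a functional assay on Raji cells (Homo sapiens) for antiproliferative activity, read by MTT assay, with a stated time of 48 h (on this read-out lower numbers stand for stronger inhibition and higher numbers for weaker inhibition), compound 1 gives 8320 nM, the highest of the two numbers shown, above compound 2 at 1870 nM. Compound 3 reaches only a limit of the assay, > 50000 nM (the limit of > 50000 nM in this assay, at which 1 of the 3 values shown sits).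

Compound 4 `CCN(CC)CCCCn1c(N)c(-c2nc3ccccc3[nH]2)c2nc(C#N)c(C#N)nc21` differs from compound 1 by 2-(diethylamino)ethyl in place of dimethylamino on a saturated chain carbon, two bonds along the chain from an aromatic nitrogen. Among the measured compounds shown here, two measured steps bear on this change: a 4.4-fold lower number from compound 1 to compound 2 (0.65 log units; beyond the scatter) and an at least 6.0-fold higher number from compound 1 to compound 3 (0.77 log units; beyond the scatter). Compound 4 keeps a diethylamino group, as compound 2 does, and carries it on a longer chain, so a modest lowering is expected, a 5.5-fold lower number from compound 1 to compound 4 (0.74 log units; beyond the scatter). Compound 4 is estimated at 1500 nM, with a range from 400 nM to 6000 nM.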

Compound 4, half-maximal inhibitory concentration: 2640 nM
Beside the measured number, compound 4's estimate is 1.8-fold (0.25 log units) below it; low and high end bracket the measured number.
By their numbers in this assay, from the lowest: compounds 2 and 4 (each within the scatter of the next); then compound 1. At a limit, above all of these: compound 3.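

With 4-(diethylamino)butyl on the shared core, the number stays lower than with the dimethylamino chain of compound 1 (a 3.2-fold lower number from compound 1 to compound 4 (0.50 log units; beyond the scatter)), and the added chain length leaves no readable difference from compound 2 (a 1.4-fold higher number from compound 2 to compound 4 (0.15 log units; within the scatter)). Placing diethylamino at the end of the plain chain gives a large step (an at least 18-fold lower number from compound 3 to compound 4 (1.27 log units; beyond the scatter)). The value of compound 3 is a limit, not a number: the limit of > 50000 nM in this assay, at which 1 of the 4 values shown sits.

Open, as far as these compounds go, is whether a ring amine such as piperidine or morpholine at the chain end would behave like diethylamino. Also open, from the compounds shown here alone, is how a still longer chain would read.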